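A few compounds are considered here, and "the series" means these few. Any claim that something is new, unique, unknown or untested is made for them only; others in the source may bear on it.

Measured so far:
- compound 1, `CN(C)CCCn1c(=O)n(C2OC(CO)[C@@H](O)[C@H]2O)c2nc(N)nc(O)c21`, in a functional assay on the whole organism (B cells) with Mus musculus as the target (on this read-out higher numbers stand for larger maximal responses and lower numbers for smaller maximal responses), gives 83%
- compound 2, `CCn1c(=O)n(C2OC(CO)[C@@H](O)[C@H]2O)c2nc(N)nc(O)c21`, in this assay gives 82%

Compound 2 gives the lower of the two numbers, but its nearest neighbour is compound 1 with a step of a number 1 percentage points lower from compound 1 to compound 2 (within the scatter), so the two are not distinguishable. For the measured compounds named here, that step, hydrogen in place of (dimethylamino)methyl on a saturated chain carbon, two bonds along the chain from an aromatic nitrogen, is the only measured step.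

Compound 3, `N#Cc1ccc(Cn2c(=O)n(C3OC(CO)[C@@H](O)[C@H]3O)c3nc(N)nc(O)c32)cc1`, is not yet measured. Its change from compound 2 is 4-cyanophenyl in place of methyl on a saturated chain carbon bound to an aromatic nitrogen. Going by the values given here, no measured step alters the carbon bound to the aromatic nitrogen, and the single measured step, at a different place on the chain, lay within the scatter. Nothing shown therefore points to a step beyond the scatter in either direction; the expectation rests on compound 2 alone, with wide uncertainty.

For compound 3 the estimated step is a number 2 percentage points lower from compound 2 to compound 3 (within the scatter) in this assay. Compound 3 is thus expected at about 80%, within a range from 60% to 95%.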

Compound 3, largest response reached (reported as maximal response), in percent of the reference or control that the assay uses: 50%
Compound 3: the middle estimate sits 30 percentage points above what was measured, outside the stated range (below it).
By their numbers in this assay, from the lowest: compound 3; then compounds 2 and 1 (each within the scatter of the next).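

Swapping methyl for 4-cyanophenyl on the saturated chain carbon bound to an aromatic nitrogen gives a large loss of response in this assay: the series shows a number 32 percentage points lower from compound 2 to compound 3 (beyond the scatter) and a number 33 percentage points lower from compound 1 to compound 3 (beyond the scatter). For the compounds shown here, the earlier step, two bonds along the chain from an aromatic nitrogen, stayed within the scatter, so this is the first sign that the response depends on the group at this place, and the loss appears only with 4-cyanobenzyl in place of the open chains. No measurement available gives a reason for the loss.

The change brings in an aromatic ring and a nitrile together, and the compounds shown do not separate the two. Plain benzyl would divide their contributions, while a longer chain or a carboxylic acid on the ring would test how far the loss extends.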